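Working notes: bromo in place of benzyloxy

The source may report more compounds than this note shows. Statements on the series, on what has been measured and on what is new or still open speak of the compounds shown alone.

Measured in an ADME assay on HEK293 cells (Homo sapiens) for cytotoxicity, read by luminescence, with a stated time of 72 h; on this read-out lower numbers stand for an effect already at smaller amounts and higher numbers for an effect only at larger amounts of compound (all three values are limits)
- compound 1 `CCOC(=O)c1c(-c2cccc(OC)c2)[nH]c2cc(OC)ccc2c1=O` gives > 22000 nM (limit)
- compound 2 `CCOC(=O)c1c(-c2cccc(OCC)c2)[nH]c2cc(OC)ccc2c1=O` gives > 22000 nM (limit)
- compound 3 `CCOC(=O)c1c(-c2cccc(OCc3ccccc3)c2)[nH]c2cc(OC)ccc2c1=O` gives > 22000 nM (limit)

Compound 3 gives > 22000 nM as a limit and not as a number. Among the measured compounds shown here, the series so far shows the limit of > 22000 nM in this assay, at which 3 of the 3 values shown sit, and nothing more. Compound 4 `CCOC(=O)c1c(-c2cccc(Br)c2)[nH]c2cc(OC)ccc2c1=O` carries bromo in place of benzyloxy on an aromatic carbon and is not yet measured. For the measured compounds named here, three measured steps touch the same substituent: a step that the two limits leave unreadable from compound 1 to compound 2 and a step that the two limits leave unreadable from compound 1 to compound 3 and a step that the two limits leave unreadable from compound 2 to compound 3 in turn. None of them replaces the chain with a halogen. Resting on a step that the two limits leave unreadable from compound 1 to compound 3 and on compound 3 at > 22000 nM as a limit, no step beyond the scatter is expected in this assay and no direction can be given. Compound 4 is expected to be reported as a limit as well. The estimated step is a step that the limit leaves unreadable from compound 3 to compound 4 and this size is only an expectation. The estimate for compound 4 is 30000 nM with an expected range of 12000 nM to 60000 nM as the working span.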

Compound 4, half-maximal effective concentration: > 22000 nM
Compound 4: no number, only a limit (the forecaster's own chance of this, stated with the estimate: 80%); the middle value lies beyond the limit too.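

Compound 4 gives > 22000 nM, which is a limit and not a number. No step can be read between compound 4 and compound 1, compound 2 or compound 3. The compounds shown leave open at what concentration any of them would show an effect, since all stop at one limit: the limit of > 22000 nM in this assay, at which 4 of the 4 values shown sit.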